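The compounds below may be only part of what the source reports. "The series", "measured", "known", "first", "only" and "open" are said of these compounds alone.

Compound 1, `Nc1ncnc2c1nc(O)n2Cc1ccccc1`, gives 10 uM in a functional assay (spleen, spleen) for activation, with Mus musculus as the target; a higher number here means that more compound is needed for the effect, a lower number that less compound is needed. Compound 2, `Nc1ncnc2c1nc(I)n2Cc1ccccc1`, gives > 10 uM in this assay, and this is a limit of the assay rather than a number.

Compound 2 therefore stands at a limit of this assay, not at a measured number. For the measured compounds named here, the only measured comparison is the step of a number no lower from compound 1 to compound 2 (the limit leaves the size open), in which iodo in place of hydroxy on an aromatic carbon left potency no better; its size cannot be read because of the limit of > 10 uM in this assay, at which 1 of the 2 values shown sits.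

Compound 3, `NNc1nc2c(N)ncnc2n1Cc1ccccc1`, has not been measured. It differs from compound 2 as follows: aminoamino in place of iodo on an aromatic carbon. Going by the values given here, no measured step shows aminoamino entering or iodo leaving, so the data give no direction for this change; the step of a number no lower from compound 1 to compound 2 (the limit leaves the size open) bears on it only by fixing where compound 2 starts, and it is itself open in size. The expectation therefore rests on the shared core alone. Compound 3 is estimated at 10 uM, with a range from 3 uM to 30 uM. This corresponds to an expected step of a number no higher from compound 2 to compound 3 (the limit leaves the size open), with a real chance that this assay again reports only a limit.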

Compound 3, minimum effective concentration: > 10 uM
Compound 3: a limit, no number (the forecaster's own chance of this, stated with the estimate: 40%); the middle value sits exactly at the limit.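

At this position, on an aromatic carbon between two ring nitrogen atoms, aminoamino joins iodo as a second group that gives only a limit in this assay. Hydroxy, in compound 1, therefore remains the only group shown here that gives a real number, and swapping it for aminoamino gave a number no lower from compound 1 to compound 3 (the limit leaves the size open). Neither step to compound 3 can be read in size, so aminoamino and iodo cannot be ranked against each other, because both compounds stop at the same limit: the limit of > 10 uM in this assay, at which 2 of the 3 values shown sit.

The compounds shown leave open how much of each compound would actually be needed for the effect, as compound 2 and compound 3 give no number to set beside that of compound 1. They also leave open whether a plain amine, a methoxy group or a carboxylic acid on this carbon would give a lower number than hydroxy or would also end at the limit.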